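This account rests on a few compounds, and the source may have more. Where it says the series, first, only, none or still open, it means among the compounds named here.

Values in a functional assay on L1210 cells (Mus musculus) for cytotoxicity; on this read-out lower numbers stand for stronger inhibition and higher numbers for weaker inhibition:
- compound 1 `COC(=O)C[C@]1(C)C[C@@](C)(CC(C)CCCC/C=C/CC/C=C\c2ccccc2)OO1`: 0.013 ug/mL
- compound 2 `COC(=O)C[C@]1(C)C[C@@](C)(CC(C)CC/C=C/CC/C=C/c2ccccc2)OO1`: 0.0043 ug/mL
- compound 3 `COC(=O)C[C@@]1(C)C[C@@](C)(CC(C)CCCC/C=C/CC/C=C\c2ccccc2)OO1`: 0.29 ug/mL

Compound 2, at 0.0043 ug/mL, holds the lowest of the three numbers and so shows the strongest inhibition. Compound 1 follows at 0.013 ug/mL, and compound 3 is highest at 0.29 ug/mL.

Next in line is compound 4 `COC(=O)C[C@@]1(C)C[C@@](C)(CC(C)CC/C=C/CC/C=C/c2ccccc2)OO1`, not yet measured. Its relation to compound 2 is the two compounds have the same atoms and bonds; at least one stereo element is drawn with a configuration in one of them and without one in the other: 1 of 5 stereo elements differ; a stereocentre at a saturated ring carbon is drawn S in compound 2 and R in compound 4. Going by the values given here, the same atoms and bonds are kept, and only that saturated ring carbon changes from S to R.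

Among the compounds with values here, one measured step bears on this: a 22-fold higher number from compound 1 to compound 3 (1.35 log units; beyond the scatter). It is the same S to R change, and the pair differs only in the fact that one of compounds 1 and 3 is drawn with a defined configuration and the other without, at the place where they differ. That step was measured on a different side chain, so its size may not carry over exactly. A similar large rise, beyond the scatter, is expected here, towards weaker inhibition.

The expected step is a 21-fold higher number from compound 2 to compound 4 (1.32 log units; beyond the scatter).

For compound 4 the estimated value is 0.09 ug/mL, with an expected range of 0.025 ug/mL to 0.3 ug/mL.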

Compound 4, half-maximal inhibitory concentration: 0.003 ug/mL
For compound 4 the middle estimate is 30-fold (1.48 log units) above the measured one; the whole stated range lies above it.
By their numbers in this assay, from the lowest: compounds 4 and 2 (each within the scatter of the next); then compound 1; then compound 3.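

In this assay, the S to R change at the saturated ring carbon gives a 1.4-fold lower number from compound 2 to compound 4 (0.16 log units; within the scatter), so with this side chain the two configurations at this position cannot be told apart. Set against a 22-fold higher number from compound 1 to compound 3 (1.35 log units; beyond the scatter), the same change has no single size across the series: the large rise seen with the side chain of compounds 1 and 3 is not a general penalty for the R configuration, and compound 4 goes against such a rule. A caveat applies to reading this step as a clean inversion: the fact that one of compounds 2 and 4 is drawn with a defined configuration and the other without, at the place where they differ

The two side chains differ in more than one place, so the compounds shown do not tell which feature sets the size of the step. Also open, going by these compounds, is how the same change behaves with a carboxylic acid in place of the methyl ester.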